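A few compounds are considered here, and "the series" means these few. Any claim that something is new, unique, unknown or untested is made for them only; others in the source may bear on it.

Measured in an ADME assay on L02 cells (Homo sapiens) for cytotoxicity, read by MTT assay, with a stated time of 24 h; on this read-out higher numbers stand for weaker inhibition and lower numbers for stronger inhibition:
Compound 1 `O=C1/C(=C/c2ccc(F)cc2)CN(S(=O)(=O)c2ccc(O[N+](=O)[O-])cc2)C/C1=C\c1ccc(F)cc1`: 16200 nM
Compound 2 `O=C1/C(=C/c2ccc(F)cc2)CN(S(=O)(=O)c2ccc(C(F)(F)F)cc2)C/C1=C\c1ccc(F)cc1`: 13500 nM
Compound 3 `O=C1/C(=C/c2ccc(F)cc2)CN(S(=O)(=O)c2ccc(Cl)cc2)C/C1=C\c1ccc(F)cc1`: 15500 nM

All three numbers lie within the scatter of one another. Compound 3 sits nearest compound 1 and furthest from compound 2, with a 1.0-fold lower number from compound 1 to compound 3 (0.02 log units; within the scatter) and a 1.1-fold higher number from compound 2 to compound 3 (0.06 log units; within the scatter), and the remaining pair gives a 1.2-fold lower number from compound 1 to compound 2 (0.08 log units; within the scatter). Compound 4 `N#Cc1ccc(S(=O)(=O)N2C/C(=C\c3ccc(F)cc3)C(=O)/C(=C/c3ccc(F)cc3)C2)cc1` differs from compound 3 by cyano in place of chloro on an aromatic carbon. The two steps that exchanged the same substituent on that ring, the one ending in chloro from nitrooxy and the one ending in chloro from trifluoromethyl, both stayed within the scatter in this assay. Three different groups at this place give one flat result, so for the cyano group no step beyond the scatter is expected; the expected step is a 1.0-fold lower number from compound 3 to compound 4 (0.01 log units; within the scatter). Compound 4 is estimated at 15000 nM, with a range from 7000 nM to 32000 nM.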

Compound 4, half-maximal inhibitory concentration: 14700 nM
The estimate for compound 4 lay 1.0-fold (0.01 log units) above the measured number; measured number inside the range.
By their numbers in this assay, from the lowest: compounds 2, 4, 3 and 1 (each within the scatter of the next).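

In this assay, within the data shown here, the cyano group, the first group here with a triple bond, reads level with each earlier group at this place: chloro (a 1.1-fold lower number from compound 3 to compound 4 (0.02 log units; within the scatter)), trifluoromethyl (a 1.1-fold higher number from compound 2 to compound 4 (0.04 log units; within the scatter)) and nitrooxy (a 1.1-fold lower number from compound 1 to compound 4 (0.04 log units; within the scatter)). Cyano also brings a hydrogen-bond acceptor that chloro lacks, and this exchange stays within the scatter, so four groups now give one flat result on this ring. Nothing at hand accounts for this flatness.

From the compounds shown here alone, whether an amine or a carboxylic acid at this place would move the number beyond the scatter remains open, as does the effect of any change elsewhere on the shared core.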